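The source may hold more compounds than are shown below. What is called first, only, known or untested is meant among the compounds shown, and "the series" means these compounds.

Measured compounds:
compound 1, `O=C(Nc1cccc(C(=O)O)c1)N[C@H]1CC[C@H](Oc2ccc(F)cc2)CC1`: > 20000 nM
compound 2, `O=C(Nc1cccc(C(F)(F)F)c1)N[C@H]1CC[C@H](Oc2cccc(F)c2)CC1`: 2400 nM

In a functional assay on CRL2813 cells (Homo sapiens) for cytotoxicity, read by sulforhodamine B assay, with a stated time of 5 days (on this read-out higher numbers stand for weaker inhibition and lower numbers for stronger inhibition), compound 1 gives > 20000 nM, which is a limit of the assay and not a number; this is the limit of > 20000 nM in this assay, at which 1 of the 2 values shown sits. Compound 1 therefore stands at the weak edge of what the data show, without a resolved value. Among the compounds with values here, compound 2, the only other compound measured in this assay, gives 2400 nM, a real number. Within the data shown here, no step between measured compounds is available, so the pair of values can only be set side by side.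

Compound 3, `O=C(Nc1ccccc1F)N[C@H]1CC[C@H](Oc2ccc(F)cc2)CC1`, differs from compound 1 in one place: 2-fluorophenyl in place of 3-carboxyphenyl on an amide-type nitrogen. For this change the expectation is a move towards stronger inhibition, taking compound 3 off the limit and into the measurable range, a step of an at least 4.0-fold lower number from compound 1 to compound 3 (0.60 log units; beyond the scatter) that is expected to exceed the usual scatter. Compound 3 is estimated at 5000 nM, in a range from 1500 nM to 20000 nM.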

Compound 3, half-maximal inhibitory concentration: 17500 nM
For compound 3 the middle estimate is 3.5-fold (0.54 log units) below the measured one; the range from low to high includes it.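

With 2-fluorophenyl in place of 3-carboxyphenyl on an amide-type nitrogen, the shared core now gives a resolved number in this assay: compound 3 gives 17500 nM. The change reads as an at least 1.1-fold lower number from compound 1 to compound 3 (0.05 log units; that floor lies within the scatter), so the data fix only a floor on its size and do not show that this change matters beyond the scatter. Compound 1 still has no number, and its value remains a limit of the assay: the limit of > 20000 nM in this assay, at which 1 of the 3 values shown sits.

The compounds shown do not separate the departure of the carboxylic acid from the arrival of the fluorine. On these data alone, how a plain phenyl or a 2-chlorophenyl would read on this nitrogen, with the rest of compound 3 kept the same, stays open.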